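The source may report more compounds than this note shows. Statements on the series, on what has been measured and on what is new or still open speak of the compounds shown alone.

Among the measured compounds shown here, in a functional assay on HT-29 cells (Homo sapiens) for inhibition, read by sulforhodamine B assay, with a stated time of 48 h (a higher number here means a weaker inhibitor of growth, a lower number a stronger inhibitor of growth), compound 1 `c1cc(OC2CCCCC2)ccc1NC1=NCCO1` gives 12600 nM, the higher of the two numbers so far, while compound 2 `c1ccc(Oc2ccc(NC3=NCCO3)cc2)cc1` gives 2000 nM. Compound 3 `O=C(CCl)NC(=O)Nc1ccc(OC2CCCCC2)cc1` keeps the cyclohexyl on oxygen of compound 1 and changes the group on the nitrogen: a group of 7 heavy atoms (3 carbon, 1 nitrogen, 2 oxygen, 1 chlorine; no ring) in place of a group of 5 heavy atoms (3 carbon, 1 nitrogen, 1 oxygen; one five-membered non-aromatic ring with 2 hetero atoms), on a nitrogen on an aromatic ring. For the measured compounds named here, the only measured step, a 6.3-fold lower number from compound 1 to compound 2 (0.80 log units; beyond the scatter), swapped cyclohexyl for phenyl at a different place, so it offers a sense of size and no direct guide. A modest move towards a lower number in this assay is expected, with wide uncertainty. The estimated step is a 3.2-fold lower number from compound 1 to compound 3 (0.50 log units; beyond the scatter). For compound 3 the expected value is 4000 nM, with a range of 1000 nM to 15000 nM.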

Compound 3, concentration for 50% growth inhibition: 3100 nM
For compound 3 the middle estimate is 1.3-fold (0.11 log units) above the measured one, within the range that was stated.
By their numbers in this assay, from the lowest: compounds 2 and 3 (each within the scatter of the next); then compound 1.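

On a nitrogen on an aromatic ring, the five-membered ring of compound 1 is not required for growth inhibition: in this assay the open-chain ((chloromethyl)carbonyl)carbamoyl group gives a 4.1-fold lower number from compound 1 to compound 3 (0.61 log units; beyond the scatter) with the cyclohexyl on oxygen unchanged. Among the compounds shown here, this is the first measured change at this position, and it is a modest gain. No available evidence explains it.

As far as these compounds go, it remains open whether the chlorine matters, which a plain methyl in place of chloromethyl would test. From the compounds shown here alone, the effect of this group alongside the phenyl on oxygen of compound 2 also remains open.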